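Taking one methyl off compound 3

This account rests on a few compounds, and the source may have more. Where it says the series, first, only, none or still open, it means among the compounds named here.

Going by the values given here, in an ADME assay on CCRF-CEM cells (Homo sapiens) for cytotoxicity, with a stated time of 3 days (a higher number here means that more compound is tolerated, a lower number that less compound is tolerated), compound 3 `Cc1ccc(Cn2c(=O)cc(C)n(C3C=CC(OC(=O)c4ccccc4)C3)c2=O)cc1` gives 20000 nM, the only exact number so far. Compound 2 `Cc1cc(=O)[nH]c(=O)n1C1C=CC(OC(=O)c2ccccc2)C1` gives > 250000 nM, which is a limit of the assay and not a number. The next structure, compound 4 `Cc1ccc(Cn2c(=O)ccn(C3C=CC(OC(=O)c4ccccc4)C3)c2=O)cc1`, has hydrogen in place of methyl on an aromatic carbon. Among the compounds with values here, only one measured step exists, an at least 12-fold lower number from compound 2 to compound 3 (1.09 log units; beyond the scatter). That step is large and beyond the scatter, but it comes from 4-methylbenzyl in place of hydrogen on an aromatic nitrogen, so it concerns another place in the molecule and bears on this change only indirectly. A closer guide is compound 1 `O=C(OC1C=CC(n2ccc(=O)n(Cc3ccccc3)c2=O)C1)c1ccccc1`, which also lacks the methyl in question and carries benzyl rather than 4-methylbenzyl. Compound 1 gives > 25000 nM, again a limit and not a number. With compound 1 at that limit of > 25000 nM, only a small change is expected in this assay, and a limit could well be the result here too. The estimated 1.3-fold higher number from compound 3 to compound 4 (0.10 log units; within the scatter) leans slightly towards more compound being tolerated, and no step beyond the scatter is expected. For compound 4 the estimate is 25000 nM, with an expected range from 10000 nM to 60000 nM.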

Compound 4, half-maximal cytotoxic concentration: > 25000 nM
Compound 4 gave a limit, no number; the forecaster's own chance of this, stated with the estimate: 50%; the middle value lies on the limit itself.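

Hydrogen in place of methyl on this aromatic carbon, next to the ring nitrogen, gives an at least 1.2-fold higher number from compound 3 to compound 4 (0.09 log units; that floor lies within the scatter). Going by these compounds alone, this is the first reading of the change with the 4-methylbenzyl group held fixed, and in this assay it gives only a floor, so the pair shows no change beyond the scatter but does not rule one out, since compound 4 has a limit rather than an exact number. The step from compound 1 to compound 4 cannot be read because both compounds sit at the same limit, so the methyl on the benzyl group can be judged no better than the one on the shared core: the limit of > 25000 nM in this assay, at which 2 of the 4 values shown sit.

The compounds shown leave open how far past its limit compound 4 really lies, and so whether losing this methyl matters much or hardly at all in this assay. They also leave open what a longer chain such as ethyl, an amine or a carboxylic acid would do on this same aromatic carbon, where only methyl and hydrogen appear here.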